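A few compounds are considered here, and "the series" means these few. Any claim that something is new, unique, unknown or untested is made for them only; others in the source may bear on it.

Measured compounds and values in a functional assay on SF-295 cells (Homo sapiens) for cytotoxicity, read by sulforhodamine B assay, with a stated time of 48 h; on this read-out lower numbers stand for stronger inhibition of growth and higher numbers for weaker inhibition of growth:

compound 1, `ClCc1ccccc1Cn1cnc2c(Cl)nc(Cl)nc21`: 1900 nM
compound 2, `ClCc1cccc(Cn2cnc3c(Cl)nc(Cl)nc32)c1`: 4360 nM
compound 3, `Nc1nc(Cl)c2ncn(Cc3ccccc3CCl)c2n1`: 7410 nM

Compound 1 and compound 2 share the same atoms joined differently; the difference between the two cores is not broken down here. Compound 2 and compound 3 lie within the scatter of one another in this assay, while compound 1 gives a lower number than either.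

The change from compound 1 to compound 3 is amino in place of chloro on an aromatic carbon. This gave a 3.9-fold higher number from compound 1 to compound 3 (0.59 log units; beyond the scatter).

Compound 4, `Nc1nc(Cl)c2ncn(Cc3cccc(CCl)c3)c2n1`, remains to be measured. It stands to compound 2 as compound 3 stands to compound 1: the change is amino in place of chloro on an aromatic carbon, the same change at the same place.

Among the compounds with values here, for compound 4 a step in this assay of roughly a 3.4-fold higher number from compound 2 to compound 4 (0.54 log units; beyond the scatter) is expected, resting on the single earlier instance of this change, which is a 3.9-fold higher number from compound 1 to compound 3 (0.59 log units; beyond the scatter), applied to compound 2 at 4360 nM. One instance is a thin basis, so the range is kept wide. The estimate for compound 4 is 15000 nM, between 6000 nM and 40000 nM.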

Compound 4, concentration for 50% growth inhibition: 3380 nM
Estimate against measurement, compound 4: 4.4-fold (0.65 log units) above; measured number below the stated range.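

In this assay, amino in place of chloro on an aromatic carbon gives a 1.3-fold lower number from compound 2 to compound 4 (0.11 log units; within the scatter), so the change does not carry its earlier size over from the core of compound 1 to the core of compound 2: the same change on two cores in this assay, a 3.9-fold higher number (0.59 log units; beyond the scatter) from compound 1 to compound 3 and a 1.3-fold lower number (0.11 log units; within the scatter) from compound 2 to compound 4, 5.0-fold (0.70 log units) apart, beyond the scatter of two such steps. Compound 1 and compound 2 share the same atoms joined differently, so in these two pairs the outcome of the swap depends on how the shared atoms are joined, and a step read on one core cannot simply be applied to the other. This does not show why the two steps differ or which of them is more typical, and two pairs give no rule for any further core.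

The compounds shown hold only chloro or amino at this place, which leaves open how a methoxy or dimethylamino group there would read on either core. Also open, from the compounds shown here alone, is whether the gap between the two steps would persist if a hydroxymethyl group stood in place of the chloromethyl group.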